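This account rests on a few compounds, and the source may have more. Where it says the series, first, only, none or still open, it means among the compounds named here.

Three compounds share one core, a urea linking a 2,6-diisopropylphenyl group to a five-membered carbon ring that carries an aryl substituent. Compound 1 `CC(C)c1ccc(C2(CNC(=O)Nc3c(C(C)C)cccc3C(C)C)CCCC2)cc1` carries a 4-isopropylphenyl group; in an assay on microsomes for inhibition of acyl-CoA:cholesterol acyltransferase (Oryctolagus cuniculus) (on this read-out lower numbers stand for stronger inhibition and higher numbers for weaker inhibition), compound 1 gives 48 nM. Compound 2 `CC(C)c1cccc(C(C)C)c1NC(=O)NCC1(c2ccc(Cl)cc2)CCCC1` carries a 4-chlorophenyl group and in this assay compound 2 gives 32 nM, a change of a 1.5-fold lower number from compound 1 to compound 2 (0.18 log units; within the scatter). Compound 3 `COc1cccc(C2(CNC(=O)Nc3c(C(C)C)cccc3C(C)C)CCCC2)c1` carries a 3-methoxyphenyl group and in this assay compound 3 gives 13 nM, the lowest of the three numbers; the steps are a 3.7-fold lower number from compound 1 to compound 3 (0.57 log units; beyond the scatter) and a 2.5-fold lower number from compound 2 to compound 3 (0.39 log units; beyond the scatter).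

Compound 4 `COc1ccc(C2(CNC(=O)Nc3c(C(C)C)cccc3C(C)C)CCCC2)cc1` has the same atoms as compound 3, joined differently: 4-methoxyphenyl in place of 3-methoxyphenyl on a saturated ring carbon. Within the data shown here, no measured step moves a methoxy group from one position of the aryl ring to another, so nothing bears on this change directly. What is known is that both compounds with a group in the 4-position of the aryl ring, compound 1 and compound 2, gave higher numbers than compound 3, by modest amounts. Compound 4 is therefore expected to give a somewhat higher number than compound 3, a step of about a 2.2-fold higher number from compound 3 to compound 4 (0.33 log units; beyond the scatter), though a result within the scatter would not surprise. The estimate for compound 4 in this assay is 28 nM, with a range from 12 nM to 70 nM.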

Compound 4, half-maximal inhibitory concentration: 31 nM
For compound 4 the middle estimate is 1.1-fold (0.04 log units) below the measured one; low and high end bracket the measured number.
By their numbers in this assay, from the lowest: compound 3; then compounds 4, 2 and 1 (each within the scatter of the next).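

Trading the 3-methoxyphenyl group for the 4-methoxyphenyl group in this assay gives a 2.4-fold higher number from compound 3 to compound 4 (0.38 log units; beyond the scatter), the first direct comparison of one group, with identical atoms, at two places on the aryl ring, and it shows that the placement of the methoxy group alone shifts the number beyond the scatter. The other two new steps show that the group carried in the 4-aryl arrangement makes no readable difference among these compounds: methoxy in place of chloro gives a 1.0-fold lower number from compound 2 to compound 4 (0.01 log units; within the scatter), and methoxy in place of isopropyl gives a 1.5-fold lower number from compound 1 to compound 4 (0.19 log units; within the scatter), so compounds 1, 2 and 4 cannot be told apart and compound 3 alone stands lower. Nothing measured here explains why the placement of the methoxy group shifts the number.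

Methoxy is the only group seen in both arrangements, so it remains open whether chloro or isopropyl would also give a lower number when moved as the methoxy group was. Also open, going by these compounds, is how an amine or a carboxylic acid on the aryl ring would compare with methoxy in this assay.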